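The source may hold more compounds than are shown below. What is called first, only, known or untested is meant among the compounds shown, and "the series" means these compounds.

Measured so far:
Compound 1 `CN(C)/C=C/C(=O)c1nn(-c2ccccc2)c(-c2ccccc2)c1C#N` gives > 100000 nM (a limit)
Compound 2 `N#Cc1c(-c2nnc(O)c3nn(-c4ccc(Cl)cc4)cc23)nn(-c2ccccc2)c1-c1ccccc1` gives 32800 nM

For the measured compounds named here, in a functional assay on OVCAR-5 cells (Homo sapiens) for inhibition, read by sulforhodamine B assay, with a stated time of 48 h (a lower number here means a stronger inhibitor of growth, a higher number a weaker inhibitor of growth), compound 2 gives 32800 nM as the only actual number so far. Compound 1 stands at > 100000 nM as a limit of the assay and not a number.

Compound 3 `N#Cc1c(-c2nnc(-c3ccccc3)c3nn(-c4ccc(Cl)cc4)cc23)nn(-c2ccccc2)c1-c1ccccc1` has phenyl in place of hydroxy on an aromatic carbon and is otherwise the same as compound 2. Going by the values given here, no measured pair shows the size of such a change, so any expectation is loose. In this assay the expected result is a modest shift towards stronger growth inhibition, read as a 2.2-fold lower number from compound 2 to compound 3 (0.34 log units; beyond the scatter) and estimated with wide uncertainty. For compound 3 the estimated value is 15000 nM with an expected range from 3000 nM to 70000 nM on this read-out.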

Compound 3, concentration for 50% growth inhibition: 8940 nM
Beside the measured number, compound 3's estimate is 1.7-fold (0.22 log units) above it; low and high end bracket the measured number.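

Working notes on the position: in this assay, phenyl in place of hydroxy on the aromatic carbon next to the ring nitrogen gives a 3.7-fold lower number from compound 2 to compound 3 (0.56 log units; beyond the scatter) as the first readable step in the series. Growth inhibition therefore does not depend on the hydroxy at this position, and the much larger phenyl is accepted with a modest gain rather than a loss. Nothing available accounts for the size of this step.

A single pair cannot separate what the loss of hydroxy contributes from what the arrival of phenyl contributes. A methyl, an amine or a methoxy at the same carbon would help to separate the two, and a substituted phenyl would show whether the ring itself can carry further change.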